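Isopropyl in Place of the Oxazole at the Same Aromatic Carbon

The compounds below may be only part of what the source reports. "The series", "measured", "known", "first", "only" and "open" are said of these compounds alone.

compound 1 `CCOc1ccccc1N1CCN(CCCNc2ncccc2C(=O)N(C)C)CC1`: 0.501 nM
compound 2 `CN(C)C(=O)c1cccnc1NCCCN1CCN(c2ccccc2-c2ncco2)CC1`: 0.316 nM

Two measured compounds share the core of compound 1 and differ only in the group carried on one aromatic carbon. In a functional assay for antagonist activity at Alpha-1A adrenergic receptor (Oryctolagus cuniculus) (a lower number here means tighter binding, a higher number weaker binding), compound 1 gives 0.501 nM, while compound 2 gives 0.316 nM. Within the data shown here, the one measured step, a 1.6-fold lower number from compound 1 to compound 2 (0.20 log units; within the scatter), is within the scatter, so the numbers of compound 2 and compound 1 cannot be told apart; compound 2 has the smaller of the two numbers, but nothing more than that can be read from them.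

Compound 3 `CC(C)c1ccccc1N1CCN(CCCNc2ncccc2C(=O)N(C)C)CC1` carries the change (isopropyl in place of 1,3-oxazol-2-yl on an aromatic carbon). Among the measured compounds shown here, the only step that bears on it is the one just described, which also exchanged the group at this aromatic carbon and moved the number by less than the scatter. On that basis a step of about a 1.6-fold higher number from compound 2 to compound 3 (0.20 log units; within the scatter) is expected, without a direction that could be trusted beyond the scatter. Compound 3 is therefore estimated at 0.5 nM in this assay, with a range from 0.2 nM to 1.5 nM.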

Compound 3, dissociation constant: 0.398 nM
Compound 3: middle estimate off by 1.3-fold (0.10 log units), on the high side; the measured number falls inside the stated range.
By their numbers in this assay, from the lowest: compounds 2, 3 and 1 (each within the scatter of the next).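

With isopropyl, this aromatic carbon, ortho to a large group, now holds a third kind of group, and one with no ring, only carbon as heavy atoms and 0 hydrogen-bond acceptors. In this assay the exchange of 1,3-oxazol-2-yl for isopropyl gives a 1.3-fold higher number from compound 2 to compound 3 (0.10 log units; within the scatter) and the exchange of ethoxy for isopropyl gives a 1.3-fold lower number from compound 1 to compound 3 (0.10 log units; within the scatter) at the same carbon. The earlier pair compared only ethoxy with 1,3-oxazol-2-yl, both of which carry oxygen, whereas these three compounds show that a group of carbon alone also cannot be told apart from them here, and no supporting evidence is available to explain this.

The three compounds shown do not say how far this tolerance extends, since an amine, a carboxylic acid or a longer alkyl chain on this carbon could still give a step beyond the scatter. They also leave open whether isopropyl would behave in the same way on another carbon of this ring, or with a change elsewhere in the shared core.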